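The source may report more compounds than this note shows. Statements on the series, on what has been measured and on what is new or still open speak of the compounds shown alone.

Measured compounds in this series:
compound 1, `CNC(=O)CC1CCc2cc(OC)c(OC)cc21`: 24.1%
compound 2, `CCCCNC(=O)CC1CCc2cc(OC)c(OC)cc21`: 24.1%

Both were run in a functional assay on the whole organism (strain Wistar) for inhibition, with Rattus norvegicus as the target, read by paw edema, with stated times of 60 min and 6 h, at a dose of 100 mg/kg by the oral route; a lower number here means less inhibition, a higher number more inhibition at the dose given (going by the name of the read-out). Compound 1 gives 24.1% there, and compound 2 gives 24.1%. The one step between them, no change at the digits printed from compound 1 to compound 2 (within the scatter), is the only step so far, so compound 1 stands level with compound 2 at the digits shown and has no other neighbour to compare with.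

Compound 3, `CCCCCCNC(=O)CC1CCc2cc(OC)c(OC)cc21`, has not yet been run. It differs from compound 1 by pentyl in place of hydrogen on a saturated chain carbon bound to an amide-type nitrogen. Going by the values given here, the only measured step that bears on this change is no change at the digits printed from compound 1 to compound 2 (within the scatter), which carries a shorter chain into the same place and shows nothing beyond the scatter. On that basis no step beyond the scatter is expected for compound 3, that is a number 0.1 percentage points lower from compound 1 to compound 3 (within the scatter). The estimate for compound 3 is therefore 24%, with a range from 12% to 36%.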

Compound 3, a percentage reported as inhibition, in the whole organism at one dose (the size of the read-out at that dose, not a potency): 38.3%
Compound 3: middle estimate off by 14.3 percentage points, on the low side; measured number above the stated range.
By their numbers in this assay, from the lowest: compounds 1 and 2 (each within the scatter of the next); then compound 3.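

In this assay, the chain on the amide-type nitrogen now shows an effect: pentyl in place of hydrogen on a saturated chain carbon bound to an amide-type nitrogen gives a number 14.2 percentage points higher from compound 1 to compound 3 (beyond the scatter), while the shorter propyl in the same place gave no change at the digits printed from compound 1 to compound 2 (within the scatter). Ethyl in place of hydrogen on a saturated chain carbon, four bonds along the chain from an amide-type nitrogen, gives a number 14.2 percentage points higher from compound 2 to compound 3 (beyond the scatter), so the response to chain extension is uneven, and compound 2 goes against a steady rise with chain length. Nothing at hand accounts for this result.

As far as these compounds go, whether a longer chain such as octyl would raise the number further or level it off remains open. Also open, from the compounds shown here alone, is how a branched chain, or an amine or carboxylic acid at the chain end, would read in this assay.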